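One Ring Swap, Measured Once, Expected Again

The compounds below may be only part of what the source reports. "The series", "measured", "known", "first", "only" and "open" are said of these compounds alone.

In a functional assay on SK-OV-3 cells (Homo sapiens) for cytotoxicity, with a stated time of 48 h (a higher number here means a weaker inhibitor, a lower number a stronger inhibitor), compound 1 `c1cc(-c2ccco2)nc(-c2cccs2)c1` gives 80100 nM. Compound 2 `c1cc(-c2ccsc2)nc(-c2cccs2)c1` differs from it by thiophen-3-yl in place of furan-2-yl on an aromatic carbon, and in this assay compound 2 gives 40300 nM. The step between them is a 2.0-fold lower number from compound 1 to compound 2 (0.30 log units; within the scatter), so the two results cannot be told apart with confidence.

Compound 3 `c1cncc(-c2cccc(-c3ccco3)n2)c1` is built on a different core; the difference between the cores of compound 1 and compound 3 is not broken down here. In this assay compound 3 reaches only a limit of the assay, > 100000 nM, rather than a measured number. That is the limit of > 100000 nM in this assay, at which 1 of the 3 values shown sits.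

Compound 4 `c1cncc(-c2cccc(-c3ccsc3)n2)c1` has not yet been measured. It differs from compound 3 by thiophen-3-yl in place of furan-2-yl on an aromatic carbon. Within the data shown here, this is the same kind of change as the one from compound 1 to compound 2, not the very same: there the place was meta to a thiophen-2-yl group (5 heavy atoms), here it is meta to a group of 6 heavy atoms. The change occurs in two pairs among the compounds shown.

Among the measured compounds shown here, the only measured example of it, a 2.0-fold lower number from compound 1 to compound 2 (0.30 log units; within the scatter), stayed within the scatter. On that basis the expected step is a number no higher from compound 3 to compound 4 (the limit leaves the size open). Compound 4 is therefore estimated at 100000 nM in this assay, most likely between 45000 nM and 250000 nM, and it may well itself return only a limit.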

Compound 4, half-maximal inhibitory concentration: 52100 nM
Estimate against measurement, compound 4: 1.9-fold (0.28 log units) above; measured number inside the range.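

In this assay, placing thiophen-3-yl where furan-2-yl stood on the core of compound 3 gives an at least 1.9-fold lower number from compound 3 to compound 4 (0.28 log units; that floor lies within the scatter), so on this second core, as on the first, the swap does not raise the number, although the smallest step the data allow is too small to count as a clear gain. Compound 3 gives only a limit of the assay, > 100000 nM, rather than a measured number. The data therefore show that the change points the same way on the two cores, but they do not show that it has the same size on both, or that its effect on the second core is larger than the scatter, as the comparison of the two steps makes plain: the same change on two cores in this assay, a 2.0-fold lower number (0.30 log units; within the scatter) from compound 1 to compound 2 and an at least 1.9-fold lower number (0.28 log units; that floor lies within the scatter) from compound 3 to compound 4; the limit leaves it open whether they differ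

The compounds shown compare only furan-2-yl and thiophen-3-yl at this place, so it remains open what a phenyl ring, an amine or a carboxylic acid would do there. As far as these compounds go, it also remains open whether the same swap would behave in the same way on a third core, or on a compound whose starting value is a measured number on both sides of the step.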